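Hydrazone aryl swap in a cytotoxicity series

This account rests on a few compounds, and the source may have more. Where it says the series, first, only, none or still open, it means among the compounds named here.

Two compounds of this series have a number in a functional assay on MKN-45 cells (Homo sapiens) for cytotoxicity, read by MTT assay, with a stated time of 72 h; on this read-out lower numbers stand for stronger inhibition and higher numbers for weaker inhibition. Compound 1 `COc1cc2c(Oc3ccc(NC(=O)N/N=C/c4ccc([N+](=O)[O-])cc4)cc3F)ccnc2cc1OCCCN1CCCC1` gives 470 nM there. Compound 2 `COc1ccc(/C=N/NC(=O)Nc2ccc(Oc3ccnc4cc(OCCCN5CCCCC5)c(OC)cc34)c(F)c2)cc1` gives 660 nM in this assay. On the bare numbers compound 2 sits at the top of the pair, but its gap to compound 1 lies within the scatter, so the two compounds cannot be told apart on this read-out. Within the data shown here, no pair among the measured compounds differs in a single place, so no measured step is available to lean on.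

Compound 3 `COc1cc2c(Oc3ccc(NC(=O)N/N=C/c4ccc(F)cc4Cl)cc3F)ccnc2cc1OCCCN1CCCCC1` is not yet measured. It differs from compound 2 by 2-chloro-4-fluorophenyl in place of 4-methoxyphenyl on a carbon with a double bond to nitrogen, with the rest of the structure unchanged. Compound 1 and compound 2, which differ in more than one place, give numbers within the scatter of each other, which leaves little basis for expecting a large step from any single change in this region. The expected step of a 1.6-fold lower number from compound 2 to compound 3 (0.20 log units; within the scatter) is of modest size, toward a somewhat lower number, and may well stay within the scatter. For compound 3 the estimate in this assay is 420 nM, within 150 nM to 1200 nM.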

Compound 3, half-maximal inhibitory concentration: 270 nM
Beside the measured number, compound 3's estimate is 1.6-fold (0.19 log units) above it; measured number inside the range.
By their numbers in this assay, from the lowest: compounds 3, 1 and 2 (each within the scatter of the next, the first and the last beyond it).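

In this assay, among these compounds, 2-chloro-4-fluorophenyl in place of 4-methoxyphenyl on the carbon with a double bond to nitrogen gives a 2.4-fold lower number from compound 2 to compound 3 (0.39 log units; beyond the scatter), the first step that can be read at a single place. It shows that the number in this assay responds to a change of the aryl group at this position, something compound 1 and compound 2 could not show, as they differ in more than one place. Nothing at hand bears on the reason for this step, and this single swap does not separate the loss of the methoxy group from the arrival of the chlorine or the fluorine.

Still open, as far as these compounds go, is how a phenyl ring carrying only the chlorine or only the fluorine would read on this carbon, which would divide the step between the two halogens. Also open, from the compounds shown here alone, are whether an aryl group bearing an amine or a carboxylic acid would continue in the same direction, and whether the step carries over to the side chain of compound 1.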